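The source may report more compounds than this note shows. Statements on the series, on what has been measured and on what is new or still open speak of the compounds shown alone.

Compound 1 `Cc1nc(C(NC(=O)C(=O)Nc2ccc(F)cc2)C2CCCCN2)sc1CCO`: in an ADME assay on TZM-b1 cells (Homo sapiens) for cytotoxicity, read by XTT assay, with a stated time of 3 days (a higher number here means that more compound is tolerated, a lower number that less compound is tolerated), compound 1 shows only a limit, > 88000 nM.
Compound 2 `Cc1nc(C(NC(=O)C(=O)Nc2ccc(F)cc2F)C2CCCCN2)sc1CO`: in this assay compound 2 shows only a limit, > 87000 nM.
Compound 3 `Cc1nc(C(NC(=O)C(=O)Nc2ccc(F)cc2F)C2CCCCN2)sc1CCO`: in this assay compound 3 shows only a limit, > 84000 nM.

Compound 2 thus stands at a limit of the assay, as do the other two measured compounds; none of the three gave an actual number, all three were tolerated up to the highest concentration tested. The two one-place steps among them, a step that the two limits leave unreadable from compound 1 to compound 3 and a step that the two limits leave unreadable from compound 2 to compound 3, cannot be sized, because of the limit of > 84000 nM in this assay, at which 1 of the 3 values shown sits, the limit of > 87000 nM in this assay, at which 1 of the 3 values shown sits, and the limit of > 88000 nM in this assay, at which 1 of the 3 values shown sits, are limits rather than numbers. Compound 4 `Cc1nc(C(NC(=O)C(=O)Nc2ccc(C(F)(F)F)cc2)C2CCCCN2)sc1CO` is not yet measured. It differs from compound 2 in one place: 4-(trifluoromethyl)phenyl in place of 2,4-difluorophenyl on an amide-type nitrogen. The measured steps bearing on this change give no readable size, so no step beyond the usual scatter can be foreseen in either direction; the expectation is that compound 4, like the three measured compounds, is tolerated up to the top of the tested range. Compound 4 is therefore estimated at about 90000 nM in this assay, with a range from 30000 nM to 200000 nM. The expected step that the limit leaves unreadable from compound 2 to compound 4 is accordingly none beyond the scatter.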

Compound 4, half-maximal cytotoxic concentration: > 75500 nM
Compound 4 ended at the assay's limit; the forecaster's own chance of this, stated with the estimate: 80%; the middle value lies beyond the limit too.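

Compound 2 and compound 4 both sit at limits in this assay rather than at actual numbers, and the step between them has no readable size. The compounds shown leave open the concentration at which any of them stops being tolerated, and whether swapping 2,4-difluorophenyl for 4-(trifluoromethyl)phenyl changes it.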